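Swapping chloro for methyl on the benzyl ether

The source may hold more compounds than are shown below. What is called first, only, known or untested is meant among the compounds shown, and "the series" means these compounds.

Compound 1 `N#Cc1ccccc1COc1cc(O)c2c(=O)c(O)c(-c3ccccc3)oc2c1` gives 22000 nM in an ADME assay on Huh-5-2 cells (Homo sapiens) for cytotoxicity, read by WST assay, with a stated time of 3 days; on this read-out lower numbers stand for higher toxicity in this test and higher numbers for lower toxicity in this test. Compound 2 `O=c1c(O)c(-c2ccccc2)oc2cc(OCc3cccc([N+](=O)[O-])c3)cc(O)c12` gives 76000 nM in this assay. Compound 3 `O=c1c(O)c(-c2ccccc2)oc2cc(OCc3ccc(Cl)cc3)cc(O)c12` reaches the limit of > 100000 nM in this assay. The step of an at least 4.5-fold higher number from compound 1 to compound 3 (0.65 log units; beyond the scatter) and the step of an at least 1.3-fold higher number from compound 2 to compound 3 (0.11 log units; that floor lies within the scatter) both end at that limit, and the limit of > 100000 nM in this assay, at which 1 of the 3 values shown sits, marks where compound 3 sits. Compound 4 `Cc1ccc(COc2cc(O)c3c(=O)c(O)c(-c4ccccc4)oc3c2)cc1` differs from compound 3 by methyl in place of chloro on an aromatic carbon. The measured steps each replace the whole aryl group on the benzyl ether, so none of them speaks directly to this small exchange. With nothing to suggest a shift, the expected step of a number no higher from compound 3 to compound 4 (the limit leaves the size open) is none beyond the scatter. Compound 4 is therefore estimated at 100000 nM in this assay, with a range from 40000 nM to 250000 nM.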

Compound 4, half-maximal cytotoxic concentration: 88000 nM
For compound 4 the middle estimate is 1.1-fold (0.06 log units) above the measured one, and the stated range covers the measured number.
By their numbers in this assay, from the lowest: compound 1; then compounds 2 and 4 (each within the scatter of the next). At a limit, above all of these: compound 3.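

The exchange of chloro for methyl can be read only as a floor, with an at least 1.1-fold lower number from compound 3 to compound 4 (0.05 log units; that floor lies within the scatter) as its sole measure, because compound 3 stands at a limit and not at a number: the limit of > 100000 nM in this assay, at which 1 of the 4 values shown sits. Chlorine is still not needed to clear compound 1, since methyl also gives a 4.0-fold higher number from compound 1 to compound 4 (0.60 log units; beyond the scatter) as its step. Against compound 2 there is no order, with a 1.2-fold higher number from compound 2 to compound 4 (0.06 log units; within the scatter) as the step. From the compounds shown here alone, whether an amine, a carboxylic acid or a longer chain in place of the methyl would keep the number this high stays open.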